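Swap of the five-membered ring on the ether arm

The compounds below may be only part of what the source reports. "The series", "measured", "known", "first", "only" and "open" are said of these compounds alone.

Measured so far:
compound 1 `COC(=O)C1=C(C)N=C(C)/C(=C(/O)OC)C1c1cccc(OCc2c(C#N)no[n+]2[O-])c1` — 11 nM
compound 2 `COC(=O)C1=C(C)N=C(C)/C(=C(/O)OC)C1c1cccc(OCc2no[n+]([O-])c2C#N)c1` — 3.3 nM
compound 3 `COC(=O)C1=C(C)N=C(C)/C(=C(/O)OC)C1c1ccccc1OCc1c(C#N)no[n+]1[O-]` — 9.4 nM

These values come from a functional assay (aorta) with Rattus norvegicus as the target, in the presence of a further agent that is not named here; a lower number here means that less compound is needed, a higher number that more compound is needed for the effect. Compound 2 arises from compound 1 by a group of 8 heavy atoms (3 carbon, 3 nitrogen, 2 oxygen; one five-membered aromatic ring with 3 hetero atoms) in place of a group of 8 heavy atoms (3 carbon, 3 nitrogen, 2 oxygen; one five-membered aromatic ring with 3 hetero atoms), on a saturated chain carbon bound to an oxygen on an aromatic ring, and in this assay this gave a 3.3-fold lower number from compound 1 to compound 2 (0.52 log units; beyond the scatter). Compound 3 rests on a different core from compound 1; the difference between the two cores is not broken down here, and the values of compound 3 and compound 1 lie within the scatter of each other.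

Compound 4 `COC(=O)C1=C(C)N=C(C)/C(=C(/O)OC)C1c1ccccc1OCc1no[n+]([O-])c1C#N`, not yet measured, carries the same change applied to compound 3: a group of 8 heavy atoms (3 carbon, 3 nitrogen, 2 oxygen; one five-membered aromatic ring with 3 hetero atoms) in place of a group of 8 heavy atoms (3 carbon, 3 nitrogen, 2 oxygen; one five-membered aromatic ring with 3 hetero atoms), on a saturated chain carbon bound to an oxygen on an aromatic ring. The place of the change is described in the same words in both pairs, so it is taken as the same change. Going by the values given here, for compound 4 the step is expected to be a 2.7-fold lower number from compound 3 to compound 4 (0.43 log units; beyond the scatter), resting on the single earlier step of a 3.3-fold lower number from compound 1 to compound 2 (0.52 log units; beyond the scatter); with only one precedent the range is kept wide. Compound 4 is therefore estimated at 3.5 nM, between 1.5 nM and 9 nM.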

Compound 4, half-maximal effective concentration: 4.4 nM
For compound 4 the middle estimate is 1.3-fold (0.10 log units) below the measured one; measured number inside the range.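

In this assay the swap of the five-membered ring on the ether arm carries over to the core of compound 3, with a 2.1-fold lower number from compound 3 to compound 4 (0.33 log units; beyond the scatter). The two steps agree in direction and in size: the same change on two cores in this assay, a 3.3-fold lower number (0.52 log units; beyond the scatter) from compound 1 to compound 2 and a 2.1-fold lower number (0.33 log units; beyond the scatter) from compound 3 to compound 4, 1.6-fold (0.19 log units) apart, within the scatter of two such steps. This supports carrying the change between these two cores in this assay only; two pairs give no rule for other cores and do not show how the swap acts.

Still open, on these data alone, is whether the step survives when the nitrile on the ring gives way to another group, such as a carboxylic acid or an amide. Also open, as far as these compounds go, is whether it holds with a longer chain in the ether arm.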